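The source may hold more compounds than are shown below. What is called first, only, known or untested is meant among the compounds shown, and "the series" means these compounds.

Working notes on the series. Compound 3 `Cc1c(C(=O)N/N=C\c2cccc(O)c2)oc2cccc(O)c12` is the reference point. In a functional assay on PC-3 cells (Homo sapiens) for inhibition (on this read-out lower numbers stand for stronger inhibition and higher numbers for weaker inhibition), compound 3 gives 17600 nM, the lowest of the two numbers; its nearest neighbour is compound 1 `Cc1c(C(=O)N/N=C\c2cc(O)ccc2O)oc2cccc(O)c12`, which in this assay gives 95500 nM. Compound 2 `Cc1c(C(=O)N/N=C\c2ccc(C(F)(F)F)cc2)oc2cccc(O)c12` gives in this assay only a limit, >= 40000 nM; this is the limit of >= 40000 nM in this assay, at which 1 of the 3 values shown sits. Going by the values given here, the one step measured, a 5.4-fold lower number from compound 1 to compound 3 (0.73 log units; beyond the scatter), removes a hydroxy from compound 1 to reach compound 3.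

Compound 4 `Cc1c(C(=O)N/N=C\c2ccccc2O)oc2cccc(O)c12` carries 2-hydroxyphenyl in place of 3-hydroxyphenyl on a carbon with a double bond to nitrogen. Among the compounds with values here, no measured step covers this exchange directly. Within the data shown here, the hydroxy that compound 4 gains is the one that compound 1 carries and compound 3 lacks, and the hydroxy that compound 4 loses is the one shared by compound 1 and compound 3, so compound 4 has no measured neighbour differing in exactly this way. The step of a 5.4-fold lower number from compound 1 to compound 3 (0.73 log units; beyond the scatter) shows that the hydroxy arriving in compound 4 did not favour compound 1, which argues for a higher number; what the loss of the other hydroxy costs remains unmeasured. A step of a 2.6-fold higher number from compound 3 to compound 4 (0.41 log units; beyond the scatter) is expected, upward, beyond the scatter. Compound 4 is therefore estimated at 45000 nM, with a range from 12000 nM to 160000 nM.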

Compound 4, half-maximal inhibitory concentration: 8350 nM
For compound 4 the middle estimate is 5.4-fold (0.73 log units) above the measured one; measured number below the stated range.
By their numbers in this assay, from the lowest: compound 4; then compound 3; then compound 1.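

The exchange of 3-hydroxyphenyl for 2-hydroxyphenyl on a carbon with a double bond to nitrogen keeps the same atoms and still gives a 2.1-fold lower number from compound 3 to compound 4 (0.32 log units; beyond the scatter), so in this assay the place of the hydroxy on this ring matters, not only its presence. Of the two hydroxy groups on the dihydroxyphenyl ring, keeping the one found in the 2-hydroxyphenyl gives an 11-fold lower number from compound 1 to compound 4 (1.06 log units; beyond the scatter), a large step, whereas keeping the other gives a 5.4-fold lower number from compound 1 to compound 3 (0.73 log units; beyond the scatter), a modest one. Nothing at hand bears on the reason for this difference.

As far as these compounds go, whether a methoxy, an amine or a carboxylic acid in place of the hydroxy of the 2-hydroxyphenyl would hold the lower number stays open. From the compounds shown here alone, the contribution of the hydroxy on the shared core also stays open.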